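Aryl carbonyl in place of phenoxymethyl carbonyl

A few compounds are considered here, and "the series" means these few. Any claim that something is new, unique, unknown or untested is made for them only; others in the source may bear on it.

Of the compounds shown here, three sharing one core have been measured in a functional assay on the whole organism (strain albino) with Mus musculus as the target, with a stated time of 0.5 h; a higher number here means that more compound is needed for the effect, a lower number that less compound is needed. Compound 1 `Cc1ccc(/C=C2/N=C(c3ccccc3)N(C(=O)COc3ccccc3)NC2=O)cc1` gives 300 mg/kg, the highest number of the three. Compound 2 `COc1ccc(/C=C2/N=C(c3ccccc3)N(C(=O)c3ccc(Cl)cc3)NC2=O)cc1` gives 100 mg/kg, and compound 3 `O=C1NN(C(=O)c2ccc(Cl)cc2)C(c2ccccc2)=N/C1=C/c1ccccc1` gives 100 mg/kg. For the measured compounds named here, the one measured step, no change at the digits printed from compound 2 to compound 3 (within the scatter), concerns a different place than the change considered here, so it bears on it only by showing that the benzylidene aryl tolerates small changes. Compound 4 `Cc1ccc(/C=C2/N=C(c3ccccc3)N(C(=O)c3ccc(C)cc3)NC2=O)cc1` differs from compound 1 by 4-methylphenyl in place of phenoxymethyl on a carbonyl carbon. Compounds 2 and 3, which both carry an aryl group on that carbonyl carbon, stand at a lower number than compound 1, though they also differ from compound 1 elsewhere, so the comparison is not clean. On this basis compound 4 is expected to move toward those two, giving an estimated 150 mg/kg, within a range from 60 mg/kg to 400 mg/kg. The expected step is a 2.0-fold lower number from compound 1 to compound 4 (0.30 log units; within the scatter), downward and beyond the scatter.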

Compound 4, dose for half-maximal effect: 30 mg/kg
Beside the measured number, compound 4's estimate is 5.0-fold (0.70 log units) above it; the whole stated range lies above it.
By their numbers in this assay, from the lowest: compound 4; then compounds 2 and 3 (each within the scatter of the next); then compound 1.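

Putting 4-methylphenyl in place of phenoxymethyl on the carbonyl carbon gives a 10-fold lower number from compound 1 to compound 4 (1.00 log units; beyond the scatter) in this assay. For the compounds shown here, this is the first comparison here in which only this group changes, so it shows directly that the choice of group at this position affects the dose needed, a step beyond the scatter. The earlier compounds shown here could only hint at this. They also differed elsewhere. Nothing measured here explains the step.

The change alters several things at once: it removes the oxygen and the chain carbon of phenoxymethyl and adds the ring methyl, and the compounds shown do not separate these parts. They also leave open how this position would respond to a longer chain between the carbonyl and the ring, or to an amine or a carboxylic acid on that ring.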